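The source may report more compounds than this note shows. Statements on the series, on what has been measured and on what is new or still open speak of the compounds shown alone.

Series values in an ADME assay on J774 cells (Mus musculus) for cytotoxicity (on this read-out lower numbers stand for an effect already at smaller amounts and higher numbers for an effect only at larger amounts of compound), each one a limit of the assay:
- compound 1 `Cc1[nH]c2ccccc2c(=O)c1/C=C/c1cccc([N+](=O)[O-])c1`: > 32600 nM
- compound 2 `Cc1[nH]c2ccccc2c(=O)c1/C=C/c1ccc(O)cc1`: > 36100 nM
- compound 3 `COc1ccc2[nH]c(C)c(Br)c(=O)c2c1`: > 37300 nM

Compound 3 has only a limit and no number, as do compounds 1 and 2. Compound 4 `Cc1[nH]c2ccc(Br)cc2c(=O)c1Br` carries bromo in place of methoxy on an aromatic carbon. Going by the values given here, no measured pair shows the effect of this exchange, so the only guide is that none of the three compounds gives a number in this assay. The an at least 1.2-fold lower number from compound 3 to compound 4 (0.09 log units; that floor lies within the scatter) is therefore expected to stay within the usual scatter, in neither direction. For compound 4 the estimated value is 30000 nM, with an expected range of 10000 nM to 45000 nM.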

Compound 4, half-maximal effective concentration in the J774 assay: > 31500 nM
Compound 4 was reported as a limit; the forecaster's own chance of this, stated with the estimate: 65%; at least 1.0-fold (0.02 log units) between middle value and limit.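

Compound 3 and compound 4 give only limits in the J774 assay and in a physicochemical assay for solubility, read by HPLC, at pH 7.4; on this read-out lower numbers stand for lower solubility and higher numbers for higher solubility. In the physicochemical assay compound 3 gives > 20000 nM, which is a limit of the assay. In the physicochemical assay compound 4 gives > 20000 nM, which is also a limit of the assay. Going by these compounds alone, no step can therefore be read for bromo in place of methoxy on an aromatic carbon. The compounds shown leave open the size and direction of this exchange in either read-out.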